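Swapping an Aromatic Ring for a Nitropiperazine in Compound 2

A few compounds are considered here, and "the series" means these few. Any claim that something is new, unique, unknown or untested is made for them only; others in the source may bear on it.

- Compound 1 `O=C(/C(=C\c1ccc([N+](=O)[O-])c(O)c1)SCc1ccc(Br)cc1)c1ccc([N+](=O)[O-])cc1`: 1000 nM
- Compound 2 `O=C(O)c1ccc(C(=O)/C(=C\c2ccc([N+](=O)[O-])c(O)c2)SCc2ccc(Br)cc2)cc1`: 10000 nM
- Compound 3 `O=C(/C(=C\c1ccc([N+](=O)[O-])c(O)c1)SCc1ccc(Br)cc1)C1CCNC1`: > 100000 nM, a limit of the assay

These values come from a functional assay on DU-145 cells (Homo sapiens) for inhibition, read by trypan blue exclusion, with a stated time of 96 h; on this read-out higher numbers stand for weaker inhibition of growth and lower numbers for stronger inhibition of growth. Of the two values that are actual numbers, the higher belongs to compound 2 at 10000 nM, and the change of carboxy in place of nitro on an aromatic carbon gave a 10-fold higher number from compound 1 to compound 2 (1.00 log units; beyond the scatter). Compound 3 has only a limit, so its true position is not known.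

The next compound to be tested is compound 4 `CN1CCN(/C=C(/SCc2ccc(Br)cc2)C(=O)c2ccc(C(=O)O)cc2)CC1[N+](=O)[O-]`. It differs from compound 2 as follows: 4-methyl-3-nitropiperazin-1-yl in place of 3-hydroxy-4-nitrophenyl on a double-bonded chain carbon bound to a double-bonded chain carbon. Within the data shown here, no measured step touches this place, so any guidance is indirect. The closest parallels are the two changes on a carbonyl carbon where pyrrolidin-3-yl replaced an aromatic group, which gave an at least 10-fold higher number from compound 2 to compound 3 (1.00 log units; beyond the scatter) and an at least 100-fold higher number from compound 1 to compound 3 (2.00 log units; beyond the scatter). Both steps ran towards weaker inhibition of growth, but they lie elsewhere on the core and rest on compound 3 alone. On the evidence of those steps, a smaller shift in the same direction is expected, and the expected step is a 3.0-fold higher number from compound 2 to compound 4 (0.48 log units; beyond the scatter). For compound 4 the estimated value is 30000 nM, with an expected range from 6000 nM to 100000 nM.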

Compound 4, concentration for 50% growth inhibition: 10000 nM
Estimate against measurement, compound 4: 3.0-fold (0.48 log units) above, within the range that was stated.
By their numbers in this assay, from the lowest: compound 1; then compounds 2 and 4 (each within the scatter of the next). At a limit, above all of these: compound 3.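

In this assay, 4-methyl-3-nitropiperazin-1-yl in place of 3-hydroxy-4-nitrophenyl gave no change at the digits printed from compound 2 to compound 4 (within the scatter). Among these compounds, this is the first reading at the double-bonded chain carbon, and it shows that, in this one pair, a non-aromatic ring with two hetero atoms and no hydrogen-bond donor can stand in for an aromatic carbon ring with one donor, with no shift beyond the scatter. The earlier replacement of an aromatic group by a non-aromatic ring, pyrrolidin-3-yl on a carbonyl carbon, instead gave an at least 10-fold higher number from compound 2 to compound 3 (1.00 log units; beyond the scatter), a step read against a limit of the assay, so such a swap is not tolerated alike at both places, and nothing shown here explains the difference.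

Whether the same exchange holds when the carbonyl carbon bears the 4-nitrophenyl group of compound 1, the lowest number among the compounds shown, remains open. Also open, as far as these compounds go, is how much the nitro group on the new ring contributes, which a plain piperazine without it, or a morpholine ring at the same place, would address.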